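The compounds below may be only part of what the source reports. "The series", "measured", "known", "first", "only" and "open" are said of these compounds alone.

Of the compounds shown here, three share one core and have been measured in a physicochemical assay for solubility, read by spectrophotometry, measured as kinetic solubility, at pH 8, tested at 500 uM; a lower number here means a less soluble compound, a higher number a more soluble compound. Compound 1 `Cn1ccc2ccc(-c3cc(Nc4ccccc4S(N)(=O)=O)cc4nccnc34)cc21` gives 6 ug/mL in this assay. Compound 2 `CN1CCCC(NS(=O)(=O)c2ccccc2Nc2cc(-c3ccc4ccn(C)c4c3)c3nccnc3c2)C1` gives 9 ug/mL. Compound 3 `CNC(=O)c1ccncc1Nc1cc(-c2ccc3ccn(C)c3c2)c2nccnc2c1` gives 4 ug/mL, the lowest of the three numbers; its gap to compound 1 lies within the scatter, while its gap to compound 2 lies beyond it. The step from compound 1 to compound 2 puts 1-methylpiperidin-3-yl in place of hydrogen on a sulfonamide nitrogen and yields a 1.5-fold higher number from compound 1 to compound 2 (0.18 log units; within the scatter). The step from compound 1 to compound 3 swaps the whole group on the aromatic nitrogen and yields a 1.5-fold lower number from compound 1 to compound 3 (0.18 log units; within the scatter).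

Compound 4 `CN1CCC(N(C)C(=O)c2ccncc2Nc2cc(-c3ccc4ccn(C)c4c3)c3nccnc3c2)C1` has not yet been measured. It differs from compound 3 in one place: 1-methylpyrrolidin-3-yl in place of hydrogen on an amide-type nitrogen. The closest measured parallel is the step from compound 1 to compound 2, where a similar saturated nitrogen-containing ring entered on a nitrogen and produced a 1.5-fold higher number from compound 1 to compound 2 (0.18 log units; within the scatter), a change that stayed inside the scatter. On that basis only a small step is expected here, if any, and compound 4 is estimated to land at 7 ug/mL, with a range from 3 ug/mL to 16 ug/mL; this estimate means an expected step of a 1.8-fold higher number from compound 3 to compound 4 (0.24 log units; within the scatter) from compound 3.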

Compound 4, solubility: 245 ug/mL
Compound 4: the middle estimate sits 35-fold (1.54 log units) below what was measured; the whole stated range lies below it.
By their numbers in this assay, from the lowest: compounds 3, 1 and 2 (each within the scatter of the next, the first and the last beyond it); then compound 4.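

At this amide-type nitrogen, putting 1-methylpyrrolidin-3-yl in place of hydrogen goes with a large move in this assay: a 61-fold higher number from compound 3 to compound 4 (1.79 log units; beyond the scatter). The earlier step that placed a saturated ring on a nitrogen, 1-methylpiperidin-3-yl on a sulfonamide nitrogen, gave only a 1.5-fold higher number from compound 1 to compound 2 (0.18 log units; within the scatter), so across these two pairs such a change does not have one fixed outcome. Nothing measured here explains why the number moved so far in the second case.

The compounds shown leave open whether the ring nitrogen matters, something a cyclopentyl or tetrahydrofuran-3-yl group on the same amide-type nitrogen would test, and whether a ring is needed at all, which an open chain such as 2-(dimethylamino)ethyl would test. Going by these compounds, it also stays open whether the difference between the two steps follows the ring size, the nitrogen that carries the ring or the rest of the molecule, a question that 1-methylpyrrolidin-3-yl on the sulfonamide nitrogen of compound 1 would begin to answer.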